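Working notes on two measured compounds and one pending

This account rests on a few compounds, and the source may have more. Where it says the series, first, only, none or still open, it means among the compounds named here.

compound 1 `Nc1cc(N)c2nc(-c3ccccc3)c(NCc3ccc(Cl)c(Cl)c3)nc2c1` — 33100 nM
compound 2 `CCOC(=O)[C@H](CCC(=O)O)NC(=O)c1ccc(Oc2nc3cc(N)cc(N)c3nc2-c2ccccc2)cc1` — 20000 nM

In a functional assay on DU-145 cells (Homo sapiens) for inhibition, read by sulforhodamine B assay, with a stated time of 48 h (on this read-out higher numbers stand for weaker inhibition of growth and lower numbers for stronger inhibition of growth), compound 1 gives 33100 nM and compound 2 gives 20000 nM; the gap between the two numbers lies within the usual scatter, so neither stands apart, compound 1 merely holding the higher of the two. Compound 3 `COc1ccc(CNc2nc3cc(N)cc(N)c3nc2-c2ccccc2)cc1` has not been measured. It differs from compound 1 by 4-methoxyphenyl in place of 3,4-dichlorophenyl on a saturated chain carbon bound to a nitrogen on an aromatic ring. Within the data shown here, no measured pair here shows a change of this kind, so there is no step to lean on. The expected step from compound 1 is a 1.1-fold lower number from compound 1 to compound 3 (0.04 log units; within the scatter), which is to say none beyond the scatter. Compound 3 is therefore estimated at 30000 nM, with a range from 10000 nM to 90000 nM.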

Compound 3, concentration for total growth inhibition: 57500 nM
For compound 3 the middle estimate is 1.9-fold (0.28 log units) below the measured one; low and high end bracket the measured number.
By their numbers in this assay, from the lowest: compounds 2, 1 and 3 (each within the scatter of the next, the first and the last beyond it).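

In this assay, the first step read at this place, 4-methoxyphenyl in place of 3,4-dichlorophenyl on a saturated chain carbon bound to a nitrogen on an aromatic ring, stays within the scatter (a 1.7-fold higher number from compound 1 to compound 3 (0.24 log units; within the scatter)). Exchanging these two groups therefore leaves the read-out of the shared core effectively unmoved. No measurement at hand accounts for this result.

The step changes both the chlorines and the methoxy group at once, so the contribution of each stays unresolved. Also open, going by these compounds, is whether a 4-chlorobenzyl group, an amine or a carboxylic acid at this place would move the number beyond the scatter.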